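Swapping a ring on the shared core: toxicity outlook

A few compounds are considered here, and "the series" means these few. Any claim that something is new, unique, unknown or untested is made for them only; others in the source may bear on it.

The piece follows two compounds that share one core and differ in a single ring. Compound 1 `CC1(c2ccc(NC(c3ccncc3)c3nnnn3C(C)(C)C)cc2)NC(=O)c2ccccc2N1` was tested in an ADME assay on J774.A1 cells (Mus musculus) for cytotoxicity, read by MTT assay, with a stated time of 72 h (on this read-out lower numbers stand for higher toxicity in this test and higher numbers for lower toxicity in this test), but the reported result for compound 1 is "not determined" (no result reported), so compound 1 has no number to stand on. A compound of a different build, compound 2 `CN1CCN(c2ccc(-c3cc(-c4ccc(C5NC(=O)c6ccccc6N5)cc4)nc(N)n3)cc2)CC1`, does have a figure: in this assay compound 2 gives 10200 nM, which serves here only as a rough sense of the scale on which such compounds are read.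

Compound 3 `CC1(c2ccc(NC(c3ccc(Cl)cc3)c3nnnn3C(C)(C)C)cc2)NC(=O)c2ccccc2N1` is the compound still to be measured. It differs from compound 1 in one place: 4-chlorophenyl in place of pyridin-4-yl on a saturated chain carbon bound to an aromatic carbon and a nitrogen on an aromatic ring. Going by the values given here, no pair of measured compounds shows the effect of this kind of change, so nothing in the data says how far or in which direction the reading should move. With no anchor for compound 1, the step is expected to be small, none beyond the usual scatter, and the direction cannot be named.

Taking the scale set by compound 2 as the only guide, compound 3 is expected to give about 20000 nM in this assay, with a range from 4000 nM to 100000 nM, and a real chance that only a limit is reported.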

Compound 3, half-maximal cytotoxic concentration: > 400000 nM
Compound 3 gave a limit, no number (the forecaster's own chance of this, stated with the estimate: 40%); middle value at least 20-fold (1.30 log units) away from the limit.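

Compound 3 gives > 400000 nM in this assay, which is a limit and not a number. Going by these compounds alone, compound 1 has no number in this assay, so no step between compound 1 and compound 3 can be read. The compounds shown leave open how far, and in which direction, 4-chlorophenyl in place of pyridin-4-yl moves this reading.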